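A few compounds are considered here, and "the series" means these few. Any claim that something is new, unique, unknown or untested is made for them only; others in the source may bear on it.

In a functional assay on SK-MEL-2 cells (Homo sapiens) for cytotoxicity (a lower number here means that less compound is needed, a higher number that more compound is needed for the effect), compound 1 `CCCCC/C=C\C/C=C\C/C=C\C[C@@]1(OC)C=CC(=O)O1` gives 2.7 ug/mL and compound 2 `CC/C=C\C/C=C\C/C=C\C/C=C\C[C@]1(OC)C=CC(=O)O1` gives 4.5 ug/mL, two numbers within the usual scatter of each other. Compound 3 `CC/C=C/C/C=C\C/C=C\C/C=C\C[C@@]1(OC)C=CC(=O)O1` has the same atoms and bonds as compound 2 and differs only in configuration as drawn: the two compounds have the same atoms and bonds and differ only in configuration as drawn: 2 of 5 stereo elements differ; a stereocentre at a saturated ring carbon is drawn R in compound 2 and S in compound 3; a double bond is drawn Z in compound 2 and E in compound 3. Among the compounds with values here, no measured pair shows the effect of such a change, so no step beyond the scatter is expected in this assay, in either direction. The estimated step is a 1.3-fold lower number from compound 2 to compound 3 (0.11 log units; within the scatter). For compound 3 the expected value is 3.5 ug/mL, with an estimated range from 1.5 ug/mL to 8 ug/mL.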

Compound 3, concentration for half-maximal effect: 14.9 ug/mL
Estimate against measurement, compound 3: 4.3-fold (0.63 log units) below; measured number outside the range, above it.
By their numbers in this assay, from the lowest: compounds 1 and 2 (each within the scatter of the next); then compound 3.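

In this assay, within the data shown here, the earlier compounds, whose numbers lie within the scatter of each other, showed no step, but this result shows that the structure can move the number beyond it. But-1-en-1-yl in place of butyl on the saturated chain carbon comes with a 5.5-fold higher number from compound 1 to compound 3 (0.74 log units; beyond the scatter) and the drawn configuration comes with a 3.3-fold higher number from compound 2 to compound 3 (0.52 log units; beyond the scatter) in a pair where nothing else changes, and the basis for reading that step as one of configuration is this: the fact that compounds 2 and 3 differ only in the configuration as drawn.

As far as these compounds go, the ring stereocentre and the double bond change together, so which of them carries the step stays open. From the compounds shown here alone, how a longer chain or an amine on the chain would read in this assay also stays open.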